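The source may report more compounds than this note shows. Statements on the series, on what has been measured and on what is new or still open speak of the compounds shown alone.

Compound 3 `COc1cc(N2C(N)=C(C#N)C(c3ccccc3Cl)C3=C2CC(C)(C)CC3=O)cc(OC)c1OC` belongs to a small set of three analogues that share one core and differ only in the group on a saturated ring carbon. In a functional assay on Ehrlich cells (Mus musculus) for cytotoxicity, tested at 10 ug/mL (a higher number here means a stronger effect of the compound at the concentration tested, a lower number a weaker effect), compound 3 gives 10%. Compound 1 `COc1cc(N2C(N)=C(C#N)C(c3ccc([N+](=O)[O-])cc3)C3=C2CC(C)(C)CC3=O)cc(OC)c1OC` gives 10% in this assay, and compound 2 `COc1cc(N2C(N)=C(C#N)C(c3cccs3)C3=C2CC(C)(C)CC3=O)cc(OC)c1OC` gives 5%. Compound 3 therefore stands level with compound 1 at the digits printed, and its step from compound 2, a number 5 percentage points higher from compound 2 to compound 3 (within the scatter), lies within the scatter, as does the step of no change at the digits printed from compound 1 to compound 3 (within the scatter).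

Compound 4 `COc1cc(N2C(N)=C(C#N)C(c3c(OC)ccc4ccccc34)C3=C2CC(C)(C)CC3=O)cc(OC)c1OC` is not yet measured. It differs from compound 3 in one place: 2-methoxynaphthalen-1-yl in place of 2-chlorophenyl on a saturated ring carbon.

Among the measured compounds shown here, the steps that bear on this change are those that swap the group on the same saturated ring carbon: a number 5 percentage points lower from compound 1 to compound 2 (within the scatter), no change at the digits printed from compound 1 to compound 3 (within the scatter) and a number 5 percentage points higher from compound 2 to compound 3 (within the scatter). All three are within the scatter, so the group at this position has so far not moved the read-out in this assay beyond the scatter. On that basis the step of no change at the digits printed from compound 3 to compound 4 (within the scatter) is expected to be none beyond the scatter, the new aryl group notwithstanding. Compound 4 is therefore estimated to give 10% in this assay, within a range from 0% to 25%.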

Compound 4, a percentage reported as activity, at one concentration (the size of the read-out at that concentration, not a potency): 0%
Compound 4: middle estimate off by 10 percentage points, on the high side, and the stated range covers the measured number.
By their numbers in this assay, from the lowest: compounds 4, 2, 1 and 3 (each within the scatter of the next).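

The 2-methoxynaphthalen-1-yl group brings 12 heavy atoms, a second six-membered aromatic ring and a hydrogen-bond acceptor to the saturated ring carbon, yet in this assay the three new steps remain small: a number 10 percentage points lower from compound 3 to compound 4 (within the scatter), a number 5 percentage points lower from compound 2 to compound 4 (within the scatter) and a number 10 percentage points lower from compound 1 to compound 4 (within the scatter). The earlier compounds had shown this only for groups with one aromatic ring, so the lack of separation now extends to a clearly larger fused aryl group, and all four compounds lie within the scatter of one another, with no order among them. Nothing at hand accounts for this flat result at the position.

The compounds shown carry only aromatic groups on this carbon, so it remains open whether a non-aromatic group such as cyclohexyl, or an aryl group bearing an amine or a carboxylic acid, would move the read-out beyond the scatter. Also open, from the compounds shown here alone, is whether replacing the cyano group with a carboxylic acid or an amide would do so, and how the compounds would compare at any other concentration.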